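This account rests on a few compounds, and the source may have more. Where it says the series, first, only, none or still open, it means among the compounds named here.

Of the compounds shown here, three have been measured in a functional assay on SF-539 cells (Homo sapiens) for inhibition, read by sulforhodamine B assay, with a stated time of 48 h; on this read-out lower numbers stand for stronger inhibition of growth and higher numbers for weaker inhibition of growth. Compound 1 `COc1cc(-c2nn(-c3cccc(NC(=O)c4ccc(Cl)c(C(F)(F)F)c4)c3)cc2-c2ccncc2)ccc1Cl` gives 4130 nM, the highest of the three numbers. Compound 2 `O=C(Nc1cccc(-n2cc(-c3ccncc3)c(-c3ccc(Cl)c(O)c3)n2)c1)Nc1cc(C(F)(F)F)cc(C(F)(F)F)c1` gives 765 nM, and compound 3 `O=C(Nc1cccc(-n2cc(-c3ccncc3)c(-c3ccc(Cl)c(O)c3)n2)c1)Nc1cccc(C(F)(F)F)c1` gives 3540 nM. Compound 1 and compound 3 are within the scatter of each other, whereas compound 2 sits clearly lower than both. Among the compounds with values here, the only single-point step among the measured compounds runs a 4.6-fold higher number from compound 2 to compound 3 (0.67 log units; beyond the scatter), so taking away one trifluoromethyl from that ring made the compound a weaker inhibitor of growth.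

The unmeasured compound 4 `COc1cc(-c2nn(-c3cccc(NC(=O)Nc4ccc(Cl)c(Cl)c4)c3)cc2-c2ccncc2)ccc1Cl` differs from compound 1 in one place: (3,4-dichlorophenyl)amino in place of 4-chloro-3-(trifluoromethyl)phenyl on a carbonyl carbon. This change swaps the group attached to the carbonyl carbon, whose other neighbour is the amide-type nitrogen, and brings in a new hydrogen-bond donor. Within the data shown here, no measured step covers exactly this exchange; the step from compound 2 to compound 3 concerns a different ring and a different group, and compounds 2 and 3 also carry a hydroxyl where compound 1 carries a methoxy, so they bear on this change only loosely. With compound 1 and compound 3 so close in value, compound 4 is expected to stay near compound 1, with a step of a 1.3-fold lower number from compound 1 to compound 4 (0.11 log units; within the scatter) that lies within the scatter. Compound 4 is therefore estimated at 3200 nM, in a range from 1200 nM to 8000 nM.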

Compound 4, concentration for 50% growth inhibition: 965 nM
For compound 4 the middle estimate is 3.3-fold (0.52 log units) above the measured one, and the stated range ends above it.
By their numbers in this assay, from the lowest: compounds 2 and 4 (each within the scatter of the next); then compounds 3 and 1 (each within the scatter of the next).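

In this assay the exchange on the carbonyl carbon of compound 1 gives a 4.3-fold lower number from compound 1 to compound 4 (0.63 log units; beyond the scatter) and so moves the read-out toward stronger inhibition of growth. Within the data shown here, the only step read earlier concerned a trifluoromethyl on a different ring, so this is the first sign that the group on this carbonyl carbon also matters for the read-out. The exchange changes several things at once, since it brings in a nitrogen carrying a hydrogen-bond donor and trades trifluoromethyl for chlorine, and nothing available here separates these parts or gives a measured reason for the gain.

The compounds shown leave open which part of the exchange carries the step, and a 4-chloro-3-(trifluoromethyl)phenylamino group on the same carbonyl carbon would help to separate the added nitrogen from the trade of trifluoromethyl for chlorine. Also open, as far as these compounds go, are how a group of another kind at this place, such as a piperidine or a simple methylamino group, would compare, and whether the step holds when the methoxy of compound 1 is replaced by a hydroxyl.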